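Changing the nitrogen substituent on a shared core

This account rests on a few compounds, and the source may have more. Where it says the series, first, only, none or still open, it means among the compounds named here.

Measured compounds in a functional assay (trachea) with Cavia porcellus as the target; on this read-out higher numbers stand for weaker inhibition and lower numbers for stronger inhibition:
- compound 1, `CCn1nc(-c2cccnc2)c2ccccc2c1=O`, gives 1320 nM
- compound 2, `CC(C)n1nc(-c2cccnc2)c2ccccc2c1=O`, gives 3090 nM
- compound 3, `CC(=O)Cn1nc(-c2cccnc2)c2ccccc2c1=O`, gives 40700 nM

Among these three numbers compound 2 stands second highest; compound 1 is nearest to it, with a 2.3-fold higher number from compound 1 to compound 2 (0.37 log units; beyond the scatter), and compound 3 is furthest, with a 13-fold higher number from compound 2 to compound 3 (1.12 log units; beyond the scatter). Compound 4, `CCOC(=O)CCCn1nc(-c2cccnc2)c2ccccc2c1=O`, has not yet been measured in this assay. It differs from compound 2 in one place: 3-(ethoxycarbonyl)propyl in place of isopropyl on an aromatic nitrogen. Going by the values given here, the steps that bear on this change are the two that bring a carbonyl into the chain on the aromatic nitrogen: a 31-fold higher number from compound 1 to compound 3 (1.49 log units; beyond the scatter) and a 13-fold higher number from compound 2 to compound 3 (1.12 log units; beyond the scatter), both large losses. The step of a 2.3-fold higher number from compound 1 to compound 2 (0.37 log units; beyond the scatter) shows that a small change in the same chain moves the number only modestly. The new chain is longer than either and carries its carbonyl within an ester, so a loss is expected for compound 4, though a smaller one than was seen for compound 3. On that basis the expected step is a 3.2-fold higher number from compound 2 to compound 4 (0.51 log units; beyond the scatter). Compound 4 is therefore estimated at 10000 nM, with a range from 3000 nM to 35000 nM.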

Compound 4, half-maximal inhibitory concentration: 10000 nM
Compound 4: the middle estimate sits on the measured number at the digits printed; low and high end bracket the measured number.
By their numbers in this assay, from the lowest: compound 1; then compound 2; then compound 4; then compound 3.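

In this assay, the 3-(ethoxycarbonyl)propyl chain, with its carbonyl inside an ester, fares clearly better than the 2-oxopropyl chain, with a 4.1-fold lower number from compound 3 to compound 4 (0.61 log units; beyond the scatter). It still gives weaker inhibition than the two simple alkyl groups, with a 3.2-fold higher number from compound 2 to compound 4 (0.51 log units; beyond the scatter) and a 7.6-fold higher number from compound 1 to compound 4 (0.88 log units; beyond the scatter). A carbonyl-bearing chain on this aromatic nitrogen therefore need not bring the full loss seen for compound 3, although two such chains are too few to establish a general pattern.

Chain length and the change from ketone to ester differ together here, so their separate contributions remain open; an unbranched alkyl chain of similar length, or a carboxylic acid in place of the ester, would help to separate them. No measured evidence is available to explain the differences among these chains.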